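The source may hold more compounds than are shown below. What is called first, only, known or untested is meant among the compounds shown, and "the series" means these compounds.

Measured compounds:
- compound 1, `CCCC(=O)NCC1CCCc2ccc(OC)cc21`, in an assay for binding affinity to melatonin receptor type 1B (Gallus gallus), read by radioligand binding (on this read-out lower numbers stand for stronger inhibition and higher numbers for weaker inhibition), gives 0.45 nM
- compound 2, `COc1ccc2c(c1)C(CNC(C)=O)CCC2`, in this assay gives 4 nM
- compound 3, `COc1ccc2c(c1)C(CNC(C)=O)C2`, in this assay gives 224 nM

Compound 2 and compound 1 share a core and differ only at the amide end: ethyl in place of hydrogen on a saturated chain carbon bound to a carbonyl carbon. That change gives an 8.9-fold lower number from compound 2 to compound 1 (0.95 log units; beyond the scatter). Compound 3 stands apart from compound 2 in its core, and the difference between the two cores is not broken down here; what the values show is that compound 3 gives the highest number of the three, well beyond the scatter from both others.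

Compound 4, `CCCC(=O)NCC1Cc2ccc(OC)cc21`, is still to be measured. It stands to compound 3 exactly as compound 1 stands to compound 2: ethyl in place of hydrogen on a saturated chain carbon bound to a carbonyl carbon. The place of the change reads the same in both pairs, so this is the same change made on the core of compound 3.

The expected step is a 9.0-fold lower number from compound 3 to compound 4 (0.95 log units; beyond the scatter), taken to match the one already seen, because the same change gave an 8.9-fold lower number from compound 2 to compound 1 (0.95 log units; beyond the scatter). From the compounds shown here alone, whether the step carries over to this core is untested. Compound 4 is therefore expected to give about 25 nM in this assay. The range expected for compound 4 is estimated to run from 8 nM to 80 nM.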

Compound 4, inhibition constant: 49 nM
The estimate for compound 4 lay 2.0-fold (0.29 log units) below the measured number; low and high end bracket the measured number.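

In this assay, ethyl in place of hydrogen on a saturated chain carbon bound to a carbonyl carbon, which is acetyl to propylcarbonyl, gives a 4.6-fold lower number from compound 3 to compound 4 (0.66 log units; beyond the scatter). Set beside the earlier step on the other core, the size of this step cannot be told apart from it: the same change on two cores in this assay, an 8.9-fold lower number (0.95 log units; beyond the scatter) from compound 2 to compound 1 and a 4.6-fold lower number (0.66 log units; beyond the scatter) from compound 3 to compound 4, 1.9-fold (0.29 log units) apart, within the scatter of two such steps This shows that the change lowers the number on both cores tested here and that the two steps agree within the scatter, but two pairs do not show that it would carry over to any further core in the series or explain how it acts.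

Still open, from the compounds shown here alone, is how the number moves when the acyl chain changes further on either core, with a longer chain such as butylcarbonyl or a ring such as cyclopropylcarbonyl in place of propylcarbonyl. Going by these compounds, the methoxy group is also common to all four compounds, so the effect of a hydroxyl or an ethoxy in its place remains unknown.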